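From 4-bromophenyl to 2,3-dimethoxyphenyl on a shared core

A few compounds are considered here, and "the series" means these few. Any claim that something is new, unique, unknown or untested is made for them only; others in the source may bear on it.

Measured so far in a functional assay on MCF7 cells (Homo sapiens) for cytotoxicity, read by MTT assay, with a stated time of 72 h (on this read-out lower numbers stand for stronger inhibition and higher numbers for weaker inhibition), and nothing else
- Compound 1 `CC(C)=C1C(=O)N(c2ccc(Cl)cc2)N(c2ccc(Cl)cc2)C1=O` gives 39600 nM
- Compound 2 `O=C1C(=Cc2ccc(Br)cc2)C(=O)N(c2ccc(Cl)cc2)N1c1ccc(Cl)cc1` gives 30400 nM

Compound 2 at 30400 nM and compound 1 at 39600 nM lie within the usual scatter of each other, so the two cannot be told apart. Among the compounds with values here, compound 3 `COc1cccc(C=C2C(=O)N(c3ccc(Cl)cc3)N(c3ccc(Cl)cc3)C2=O)c1OC` has 2,3-dimethoxyphenyl in place of 4-bromophenyl on a double-bonded chain carbon bound to a double-bonded ring carbon as its only difference from compound 2. Within the data shown here, no measured pair differs in just one place, so the data offer no direct guide, and in this assay no step beyond the scatter is expected. The expected step is a 1.1-fold lower number from compound 2 to compound 3 (0.04 log units; within the scatter) by this estimate. The estimate for compound 3 is 28000 nM with a range from 10000 nM to 70000 nM expected.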

Compound 3, half-maximal inhibitory concentration: 11900 nM
Compound 3: the middle estimate sits 2.4-fold (0.37 log units) above what was measured; measured number inside the range.
By their numbers in this assay, from the lowest: compound 3; then compounds 2 and 1 (each within the scatter of the next).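

In this assay, 2,3-dimethoxyphenyl in place of 4-bromophenyl on a double-bonded chain carbon bound to a double-bonded ring carbon gives a 2.6-fold lower number from compound 2 to compound 3 (0.41 log units; beyond the scatter), a modest step. Within the data shown here, this is the first sign that the group at this position can change the number, which the earlier compounds could not show, as no two of them differed in just one place. Nothing measured here says why the number moved. As far as these compounds go, whether one methoxy group alone would do as much stays open, and so does what a phenyl ring carrying an amine or a carboxylic acid would give.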